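Swapping the Aniline Arm on a Shared Core

This account rests on a few compounds, and the source may have more. Where it says the series, first, only, none or still open, it means among the compounds named here.

Two analogues built on a shared core carrying a trifluoromethyl-substituted benzylthio group have been tested in a functional assay on MDA-MB-231 cells (Homo sapiens) for cytotoxicity, read by MTT assay, with a stated time of 72 h; on this read-out lower numbers stand for stronger inhibition and higher numbers for weaker inhibition. Compound 1 `CCCCCCCCCCCCCCNc1nc(SCc2ccc(C(F)(F)F)cc2)nc2ccccc12` bears a tetradecylamino chain, and in this assay compound 1 reaches only > 50000 nM, a limit of the assay rather than a number. Compound 2 `Cc1ccccc1Nc1nc(SCc2ccc(C(F)(F)F)cc2)nc2ccccc12` carries a 2-methylphenylamino group in that place, and in this assay compound 2 gives 27100 nM. Among the results shown, compound 2 therefore holds the only measured number. The other result is the limit of > 50000 nM in this assay, at which 1 of the 2 values shown sits, and it belongs to compound 1.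

Compound 3 `CCOc1ccc(Nc2nc(SCc3ccc(C(F)(F)F)cc3)nc3ccccc23)cc1` has not yet been measured. It differs from compound 2 by 4-ethoxyphenyl in place of 2-methylphenyl on a nitrogen on an aromatic ring; the same difference read one bond further out is (2-methylphenyl)amino to (4-ethoxyphenyl)amino. For the measured compounds named here, no step between measured compounds is available to guide the direction. For compound 3 the expected step is a 1.1-fold lower number from compound 2 to compound 3 (0.04 log units; within the scatter), small enough to fall within the usual scatter in either direction. In this assay compound 3 is estimated at 25000 nM, with a range from 10000 nM to 60000 nM.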

Compound 3, half-maximal inhibitory concentration: 23000 nM
For compound 3 the middle estimate is 1.1-fold (0.04 log units) above the measured one; measured number inside the range.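

For the compounds shown here, for the first time, a measured step is available at this position, on a nitrogen on an aromatic ring: a 1.2-fold lower number from compound 2 to compound 3 (0.07 log units; within the scatter) in this assay. The change replaces 2-methylphenyl with 4-ethoxyphenyl, bringing in more heavy atoms, an oxygen and a hydrogen-bond acceptor, yet the two compounds remain within the usual scatter of each other, so this one pair gives no sign that the read-out distinguishes these two aryl groups. Nothing measured here bears on why the two values stand so close, and no cause can be given for it.

The compounds shown leave open whether any group on this nitrogen can carry the number clear of the scatter, for instance a phenyl ring bearing a carboxylic acid or an amine, or an alkyl chain shorter than the tetradecyl chain of compound 1, whose result remains a limit of the assay and not a number. They also leave open whether the methyl and ethoxy groups count separately from where each sits, since this single step changes the substituent and its place on the ring together.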